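From Acetamido to Carbonyloxy: Expected Loss of Stability

This account rests on a few compounds, and the source may have more. Where it says the series, first, only, none or still open, it means among the compounds named here.

Measured in an ADME assay on cells (Hepatocyte, Homo sapiens) for metabolic stability, with a stated time of 30 min; on this read-out higher numbers stand for a more stable compound and lower numbers for a less stable compound:
compound 1 `NC1CCC(CN2CCN(c3cc(=O)c4cc(C(F)(F)F)cc([N+](=O)[O-])c4s3)CC2)CC1`: 83.6%
compound 2 `O=C(OC1CCC(CN2CCN(c3cc(=O)c4cc(C(F)(F)F)cc([N+](=O)[O-])c4s3)CC2)CC1)C1CCCCC1`: 2.8%
compound 3 `CC(=O)NC1CCC(CN2CCN(c3cc(=O)c4cc(C(F)(F)F)cc([N+](=O)[O-])c4s3)CC2)CC1`: 86.8%

Compound 3 has the highest of the three numbers in this assay, though compound 1 is close, with a number 3.2 percentage points higher from compound 1 to compound 3 (within the scatter). Compound 2 stands far apart, and a number 84 percentage points higher from compound 2 to compound 3 (beyond the scatter).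

Compound 4 `COc1ccc(C(=O)OC2CCC(CN3CCN(c4cc(=O)c5cc(C(F)(F)F)cc([N+](=O)[O-])c5s4)CC3)CC2)cc1` differs from compound 3 on the saturated ring carbon: ((4-methoxyphenyl)carbonyl)oxy in place of acetamido on a saturated ring carbon.

For the measured compounds named here, two measured steps bear on this. Going from an amino group to (cyclohexylcarbonyl)oxy gave a number 80.8 percentage points lower from compound 1 to compound 2 (beyond the scatter), and returning from that group to acetamido gave a number 84 percentage points higher from compound 2 to compound 3 (beyond the scatter). Compound 4 carries a ((4-methoxyphenyl)carbonyl)oxy group, which like (cyclohexylcarbonyl)oxy has no hydrogen-bond donor, so a large downward step in this assay is expected, beyond the scatter. Going by the values given here, no measured compound tests whether the aromatic ring in the new group behaves differently from the saturated ring of compound 2.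

Compound 4 is therefore estimated at 6%, within 0.5% to 30%, which means an expected step of a number 80.8 percentage points lower from compound 3 to compound 4 (beyond the scatter).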

Compound 4, percent of the compound remaining: 12.2%
For compound 4 the middle estimate is 6.2 percentage points below the measured one; low and high end bracket the measured number.
By their numbers in this assay, from the lowest: compounds 2 and 4 (each within the scatter of the next); then compounds 1 and 3 (each within the scatter of the next).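

In this assay, replacing cyclohexyl with 4-methoxyphenyl on the carbonyl carbon gave a number 9.4 percentage points higher from compound 2 to compound 4 (within the scatter), so the low read-out of compound 2 is not tied to the saturated ring and also appears with an aromatic ring in this group. On the saturated ring carbon, the new group gave a number 74.6 percentage points lower from compound 3 to compound 4 (beyond the scatter) and, against the amino group, a number 71.4 percentage points lower from compound 1 to compound 4 (beyond the scatter), which places both carbonyloxy compounds well apart from compound 1 and compound 3. No measurement shown here speaks to the reason for these steps.

The compounds shown leave open whether the low numbers follow the carbonyloxy link itself or the larger ring-bearing group it carries. A 4-methoxybenzamido group or a small acetoxy group on the same saturated ring carbon would separate these two readings.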